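This account rests on a few compounds, and the source may have more. Where it says the series, first, only, none or still open, it means among the compounds named here.

Measured so far in a functional assay on KYSE-450 cells (Homo sapiens) for inhibition, read by MTT assay, with a stated time of 48 h; on this read-out lower numbers stand for stronger inhibition and higher numbers for weaker inhibition:
- compound 1, `COc1ccc(CN(C(=O)CCl)c2cc(OC)c(OC)c(OC)c2)cc1O`: 210 nM
- compound 2, `C/C=C/C(=O)N(Cc1cc(OC)c(OC)c(OC)c1)c1ccc(OC)c(O)c1`: 9160 nM
- compound 3, `COc1ccc(CNc2cc(OC)c(OC)c(OC)c2)cc1Br`: 39800 nM

Compound 1 gives the lowest number of the three in this assay; compound 2 gives a higher number than compound 1, beyond the scatter, and compound 3 gives the highest number of the set, also beyond the scatter. For the measured compounds named here, all three share the same core, and the differences among them lie in the group on the nitrogen and in the substituent pattern of the benzyl ring, with no single-point step between any pair.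

The unmeasured compound 4, `COc1ccc(CN(C(=O)C[Se]C#N)c2cc(OC)c(OC)c(OC)c2)cc1O`, derives from compound 1 by one change: a group of 3 heavy atoms (1 carbon, 1 nitrogen, 1 selenium; no ring) in place of one chlorine atom, on a saturated chain carbon bound to a carbonyl carbon. The chloroacetamide of compound 1 is thus replaced by a selenocyanate-bearing acetamide of the same length, the rest of the molecule untouched.

Going by the values given here, no measured pair in the set isolates this change, so the expectation rests on compound 1 alone. Compound 4 is expected to stay in the range of compound 1, with a modest move toward a higher number in this assay, a 2.4-fold higher number from compound 1 to compound 4 (0.38 log units; beyond the scatter). The estimate for compound 4 is 500 nM, with a range from 100 nM to 2500 nM.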

Compound 4, half-maximal inhibitory concentration: 280 nM
For compound 4 the middle estimate is 1.8-fold (0.25 log units) above the measured one, within the range that was stated.
By their numbers in this assay, from the lowest: compounds 1 and 4 (each within the scatter of the next); then compound 2; then compound 3.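

In this assay, the group of 3 heavy atoms (1 carbon, 1 nitrogen, 1 selenium) in place of one chlorine atom, on a saturated chain carbon bound to a carbonyl carbon, gives a 1.3-fold higher number from compound 1 to compound 4 (0.12 log units; within the scatter) and so leaves no readable difference at this position. The earlier compounds shown here offered no step in one place, so they could not show this; the present step shows that the low number of compound 1 in this assay does not depend on the chloro group alone, since a group with a different atom count, a triple bond and a hydrogen-bond acceptor reads alike at the same place. Nothing available accounts for this likeness between the two groups.

Open, from the compounds shown here alone, is how a plain hydrogen or a thiocyanate, with sulfur standing for the selenium, would read at this place on the core of compound 1, which would show whether the entering group or the chloro group contributes anything to the number at all. Equally open, going by these compounds, is how a longer chain between the carbonyl and either group would read against compound 1 and compound 4.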